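This account rests on a few compounds, and the source may have more. Where it says the series, first, only, none or still open, it means among the compounds named here.

Measured so far in an ADME assay on HEK-293T cells (Homo sapiens) for cytotoxicity, read by MTT assay, tested at 100 uM; on this read-out lower numbers stand for a stronger effect and higher numbers for a weaker effect at the one concentration tested: compound 2 `CC(=O)Oc1ccc(Cl)cc1C(=O)Nc1ncc([N+](=O)[O-])s1` at 31.2%; compound 3 `O=C(Nc1ncc([N+](=O)[O-])s1)c1ccc(-c2ccc(Cl)cc2)o1` at 74.1%; compound 1 `O=C(Nc1ncc([N+](=O)[O-])s1)c1ccc(Cl)cc1O` with its result given as "not determined" (no result reported).

For the measured compounds named here, of the two numbers known, compound 3 holds the higher one, and in this assay compound 2 gives 31.2%, a gap beyond the scatter, so compound 3 shows the weaker effect of the pair. Compound 4 `COOc1ccc(-c2ccc(C(=O)Nc3ncc([N+](=O)[O-])s3)o2)cc1` has not yet been measured. It differs from compound 3 in one place, (methoxyoxy in place of chloro on an aromatic carbon), on an aromatic carbon of a six-membered aromatic ring of carbon only. Going by the values given here, no measured pair shows this change, so nothing about its size is known here. The step from compound 3 to compound 4 is expected to be none beyond the scatter, a number 4.1 percentage points lower from compound 3 to compound 4 (within the scatter). Compound 4 is estimated to give 70%, within 45% to 95%.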

Compound 4, a percentage reported as activity, at one concentration (the size of the read-out at that concentration, not a potency): 95.7%
Estimate against measurement, compound 4: 25.7 percentage points below; the measured number lies above the stated range.
By their numbers in this assay, from the lowest: compound 2; then compound 3; then compound 4.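

With methoxyoxy in place of chloro on an aromatic carbon, para to a large group, this assay gives a number 21.6 percentage points higher from compound 3 to compound 4 (beyond the scatter). For the compounds shown here, this is the first measured pair to change at this position, and it shows that the read-out responds to the group placed there, with a weaker effect at the one concentration tested. Nothing given here accounts for the size of this step.

The compounds shown leave open whether the step belongs to methoxyoxy in particular. Where an amine or a carboxylic acid at this position would fall relative to compound 3 and compound 4 also remains unknown.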